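Notes on a fused-ring series in the paw-edema test

The compounds below may be only part of what the source reports. "The series", "measured", "known", "first", "only" and "open" are said of these compounds alone.

Measured so far:
- compound 1, `Cc1ccc2c(Cc3nn4c(C=O)c(-c5ccc(Cl)cc5)nc4s3)coc2c1`: 47.2%
- compound 2, `Cc1ccc2c(Cc3nn4c(C=O)c(-c5ccc(Br)cc5)nc4s3)coc2c1`: 10.3%

In a functional assay on the whole organism (strain Wistar albino) for inhibition, with Rattus norvegicus as the target, read by paw edema, with a stated time of 4 h, at a dose of 100 mg/kg by the oral route (a higher number here means more inhibition at the dose given (going by the name of the read-out), a lower number less inhibition), compound 1 stands highest of the two numbers measured; its nearest neighbour is compound 2, which lies lower by a number 36.9 percentage points lower from compound 1 to compound 2 (beyond the scatter), a step that only exchanges the halogen on the 4-halophenyl group.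

The next compound, compound 3, `Cc1ccc2c(Cc3nn4c(/C=N/O)c(-c5ccc(Cl)cc5)nc4s3)coc2c1`, is not yet measured. It differs from compound 1 by a group of 3 heavy atoms (1 carbon, 1 nitrogen, 1 oxygen; no ring) in place of a group of 2 heavy atoms (1 carbon, 1 oxygen; no ring), on an aromatic carbon. The place is an aromatic carbon of the five-membered aromatic ring, next to the ring atom that bears a 4-chlorophenyl group, and the 4-chlorophenyl group itself is kept.

Among the compounds with values here, no measured step touches the formyl position, so the halogen step from compound 1 to compound 2 does not bear on this change; it only shows how far a single small exchange on this core can move the read-out. Within the data shown here, with no direct precedent, the expected step of a number 5.2 percentage points lower from compound 1 to compound 3 (within the scatter) is set to none beyond the scatter, and the range is kept wide. Compound 3 is therefore estimated at 42%, between 18% and 66%.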

Compound 3, a percentage reported as inhibition, in the whole organism at one dose (the size of the read-out at that dose, not a potency): 11.1%
Compound 3: the middle estimate sits 30.9 percentage points above what was measured, and the stated range ends above it.
By their numbers in this assay, from the lowest: compounds 2 and 3 (each within the scatter of the next); then compound 1.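

In this assay, formyl on the aromatic carbon of the five-membered aromatic ring was replaced by the group of 3 heavy atoms (1 carbon, 1 nitrogen, 1 oxygen), with the 4-chlorophenyl group kept, giving a number 36.1 percentage points lower from compound 1 to compound 3 (beyond the scatter). Within the data shown here, this is the first measured step at this position, and it shows that the read-out is not indifferent to a small exchange here: the halogen is not the only place on the shared core where one change gives a large step at the dose tested. No measurement on hand accounts for this loss of inhibition.

A single pair cannot separate the possible contributions of the added hydrogen-bond donor, the added acceptor or the added heavy atom, and a hydroxymethyl group, a carboxylic acid or an amine at the same carbon would help to tell these apart. Also open, on these data alone, is whether the step seen with the 4-chlorophenyl group carries over to the 4-bromophenyl partner of compound 2, and how either change would read across other doses.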